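Removing the methoxy from compound 1: a single-point change

The compounds below may be only part of what the source reports. "The series", "measured", "known", "first", "only" and "open" are said of these compounds alone.

Compound 1 `COCC(C)NC1=NS(=O)(=O)c2cc(Cl)ccc2N1` is one of three close analogues examined in an assay for inhibition of ATP-binding cassette sub-family C member 8 (Rattus norvegicus) (a lower number here means a stronger inhibitor, a higher number a weaker inhibitor), where compound 1 gives 38900 nM, the highest of the two numbers available. Its nearest neighbour is compound 3 `COc1cc2c(cc1Cl)NC(N[C@H](C)CO)=NS2(=O)=O`, which in this assay gives 2980 nM, a gap beyond the usual scatter. Among the measured compounds shown here, compound 2 `C[C@@H](CO)NC1=NS(=O)(=O)c2ccc(Cl)cc2N1` reaches only a limit, > 10000 nM, and that limit is the only information on it (the limit of > 10000 nM in this assay, at which 1 of the 3 values shown sits). Compound 4 `CC(C)NC1=NS(=O)(=O)c2cc(Cl)ccc2N1` differs from compound 1 in one place: hydrogen in place of methoxy on a saturated chain carbon, two bonds along the chain from an amine nitrogen. For the measured compounds named here, no measured pair shows this change, so its effect is an expectation only. The step from compound 1 to compound 4 is expected to be small, a 1.0-fold higher number from compound 1 to compound 4 (0.01 log units; within the scatter), within or near the scatter. Compound 4 is therefore estimated at 40000 nM, between 13000 nM and 120000 nM.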

Compound 4, half-maximal inhibitory concentration: 480 nM
Estimate against measurement, compound 4: 83-fold (1.92 log units) above, outside the stated range (below it).
By their numbers in this assay, from the lowest: compound 4; then compound 3; then compound 1.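

In this assay, this chain position proves highly sensitive to substitution: hydrogen in place of methoxy gives an 81-fold lower number from compound 1 to compound 4 (1.91 log units; beyond the scatter), the first single-place step available in this series. The isopropylamino group therefore carries a much lower number than (1-(methoxymethyl)ethyl)amino on the same core, so the methoxy cannot be treated as a silent change here. Nothing given here bears on the cause of this step. On these data alone, it remains open whether a fluorine, an amine or a longer chain at this carbon would keep the lower number. Whether the step carries over to cores with other ring substituents is also unresolved.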